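This account rests on a few compounds, and the source may have more. Where it says the series, first, only, none or still open, it means among the compounds named here.

In a functional assay on CCRF-CEM cells (Homo sapiens) for cytotoxicity (a lower number here means that less compound is tolerated, a higher number that more compound is tolerated), compound 1 `O=C1c2ccccc2NS(=O)(=O)N1COCCO` gives > 200 ug/mL as a limit of the assay and not a number. Compound 2 `O=C1c2ccccc2N(COCc2ccccc2)S(=O)(=O)N1Cc1ccccc1` gives 25 ug/mL with different groups on the shared core. Compound 3 `CC(=O)OCCOCN1C(=O)c2ccccc2NS1(=O)=O` differs from compound 1 by acetyl in place of hydrogen on an oxygen on a saturated carbon in the change of 2-hydroxyethyl to 2-acetoxyethyl, with acetyl in place of hydrogen on an oxygen on a saturated carbon. Among the compounds with values here, no measured pair isolates this change, so only a modest fall in tolerated concentration is expected. The estimated step is an at least 1.5-fold lower number from compound 1 to compound 3 (0.18 log units; that floor lies within the scatter) as a rough expectation. In this assay compound 3 is estimated at 130 ug/mL with a range of 50 ug/mL to 300 ug/mL as expected.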

Compound 3, half-maximal cytotoxic concentration: > 200 ug/mL
Compound 3: only a limit was reported (the forecaster's own chance of this, stated with the estimate: 45%); middle value at least 1.5-fold (0.18 log units) from the limit.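

No step can be read from compound 1 to compound 3, since both results in this assay are limits of the assay: the limit of > 200 ug/mL in this assay, at which 2 of the 3 values shown sit.

From the compounds shown here alone, whether the change from 2-hydroxyethyl to 2-acetoxyethyl shifts the tolerated concentration at all, and by how much, stays open.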